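Ethynyl Linker Replacing a Direct Biaryl Bond in the Shared Core

The source may report more compounds than this note shows. Statements on the series, on what has been measured and on what is new or still open speak of the compounds shown alone.

Measured compounds:
- compound 1, `Cn1cncc1C(OCc1ccc(C#N)cc1C#CC(C)(C)C)c1ccc(C#N)cc1`: 76.9 nM
- compound 2, `Cn1cncc1C(OCc1ccc(C#N)cc1C#Cc1ccc(-c2ccccc2)cc1)c1ccc(C#N)cc1`: > 0.1 nM
- compound 3, `Cn1cncc1C(OCc1ccc(C#N)cc1-c1ccc(C#N)cc1)c1ccc(C#N)cc1`: < 0.1 nM

In a functional assay on NIH3T3 cells (Mus musculus) (on this read-out lower numbers stand for an effect already at smaller amounts and higher numbers for an effect only at larger amounts of compound), compound 1 gives 76.9 nM. Compound 2 gives a value that is only a limit of this assay, > 0.1 nM (the limit of > 0.1 nM in this assay, at which 1 of the 3 values shown sits). Compound 3 likewise gives only a limit, < 0.1 nM (the limit of < 0.1 nM in this assay, at which 1 of the 3 values shown sits). The step of an at least 760-fold lower number from compound 1 to compound 3 (2.88 log units; beyond the scatter) shows how far compound 3 lies from compound 1; the step that the limit leaves unreadable from compound 1 to compound 2 cannot be sized.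

Compound 4, `Cn1cncc1C(OCc1ccc(C#N)cc1C#Cc1ccc([N+](=O)[O-])cc1)c1ccc(C#N)cc1`, has not yet been measured. It differs from compound 3 at one position: 2-(4-nitrophenyl)ethynyl in place of 4-cyanophenyl on an aromatic carbon. Both measured steps bear on this change, since compound 4 carries an aryl group on a triple-bonded carbon as compound 2 does, while compound 3 carries its aryl directly on the core. Because compound 2 and compound 3 both sit at limits, the gap between a direct aryl and an ethynyl-linked aryl cannot be read. The account therefore expects compound 4 to stay in the low range, and the expected step of an at least 10-fold higher number from compound 3 to compound 4 (1.00 log units; beyond the scatter) is what that expectation means. For compound 4 the expected value is 1 nM, with an estimated range from 0.1 nM to 10 nM.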

Compound 4, half-maximal effective concentration: 36 nM
Compound 4: the middle estimate sits 36-fold (1.56 log units) below what was measured; the whole stated range lies below it.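

In this assay, for the compounds shown here, compound 4 gives the first readable number for an aryl group carried on a triple bond at this position, ortho to a large group, and the change from the directly attached 4-cyanophenyl gives an at least 360-fold higher number from compound 3 to compound 4 (2.55 log units; beyond the scatter). Exchanging tert-butyl for 4-nitrophenyl on the triple-bonded carbon moves the number far less, with a 2.1-fold lower number from compound 1 to compound 4 (0.33 log units; beyond the scatter), so the two compounds with a readable ethynyl substituent stay much closer to each other than compound 4 does to the directly attached aryl of compound 3. The large step remains a bound and not an exact size, since compound 3 carries only a limit: the limit of < 0.1 nM in this assay, at which 1 of the 4 values shown sits.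

The step from compound 2 to compound 4, like the earlier step from compound 1 to compound 2, cannot be read, since compound 2 carries only a limit: the limit of > 0.1 nM in this assay, at which 1 of the 4 values shown sits. The compounds shown also leave open how much of the rise belongs to the ethynyl linker and how much to nitro standing where the direct aryl carries a nitrile, a question that a 2-(4-cyanophenyl)ethynyl group, or an amine in place of the nitro, would bear on.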